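Swapping the saturated ring on the pyridine of compound 3

A few compounds are considered here, and "the series" means these few. Any claim that something is new, unique, unknown or untested is made for them only; others in the source may bear on it.

Measured compounds:
compound 1 `CN1CCN(c2ccc(Nc3ncc4c(n3)N(C3CCCC3)CC(=O)N4)cc2)CC1` gives 5220 nM in a functional assay on HT-29 cells (Homo sapiens) for inhibition, read by MTT assay, with a stated time of 48 h; a lower number here means a stronger inhibitor, a higher number a weaker inhibitor;
compound 2 `O=C1CN(C2CCCC2)c2nc(Nc3ccc(N4CCCCC4)cc3)ncc2N1` gives 5540 nM in this assay;
compound 3 `O=C1CN(C2CCCC2)c2nc(Nc3ccc(N4CCCCC4)cn3)ncc2N1` gives 21100 nM in this assay.

Among these three, compound 3 carries the highest number: compound 2 sits at a lower number, compound 1 at a lower number still, and both gaps lie beyond the usual scatter. Compound 4 `O=C1CN(C2CCCC2)c2nc(Nc3ccc(N4CCNCC4)cn3)ncc2N1` has not yet been measured in this assay. It differs from compound 3 in one place: piperazin-1-yl in place of piperidin-1-yl on an aromatic carbon. Going by the values given here, the one measured step that bears on this exchange of one six-membered saturated ring for another is a 1.1-fold higher number from compound 1 to compound 2 (0.03 log units; within the scatter); that step went the other way and on a ring carbon of a different six-membered aromatic ring, so it is only a loose guide. On that basis no shift beyond the scatter is expected in this assay, and compound 4 is estimated at 18000 nM, with a likely range from 7000 nM to 50000 nM. The step this expectation means is a 1.2-fold lower number from compound 3 to compound 4 (0.07 log units; within the scatter).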

Compound 4, half-maximal inhibitory concentration: > 30000 nM
Compound 4: no number, only a limit; the forecaster's own chance of this, stated with the estimate: 15%; middle value at least 1.6-fold (0.22 log units) from the limit.
By their numbers in this assay, from the lowest: compounds 1 and 2 (each within the scatter of the next); then compound 3. At a limit, above all of these: compound 4.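

In this assay compound 4 is reported only as a limit, > 30000 nM. Exchanging piperidin-1-yl for piperazin-1-yl on this aromatic carbon gives an at least 1.4-fold higher number from compound 3 to compound 4 (0.15 log units; that floor lies within the scatter), so the free piperazin-1-yl brings no lower number here, a point that the earlier step between 4-methylpiperazin-1-yl and piperidin-1-yl, on a different aromatic ring, could not show. How far compound 4 lies from compound 3 stays unknown, and even a real difference cannot be claimed, because its value stops at the limit of the assay: the limit of > 30000 nM in this assay, at which 1 of the 4 values shown sits.

The compounds shown leave open whether 4-methylpiperazin-1-yl, morpholin-4-yl or an open-chain amine such as dimethylamino at this position would give a lower number than compound 3. They also leave open whether any group here would reach the numbers of compound 1 and compound 2.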